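Benzyl ether series: fluoro on the benzyl ring

The source may hold more compounds than are shown below. What is called first, only, known or untested is meant among the compounds shown, and "the series" means these compounds.

Compound 1 `Cc1nc2c(OCc3ccccc3)cccn2c1N` is the reference point of the pair measured so far. In a functional assay on the whole organism with Canis familiaris (Canis lupus familiaris) as the target, at a dose of 2 mg/kg by the intravenous route (on this read-out higher numbers stand for a stronger effect at the one dose given and lower numbers for a weaker effect), compound 1 gives 97%, the higher of the two numbers in hand. Among the compounds with values here, the only companion is compound 2 `CC(C)c1nc2c(OCc3ccccc3)cccn2c1N`, which carries an isopropyl in place of methyl on an aromatic carbon of the shared core; in this assay compound 2 gives 24%, and the step of a number 73 percentage points lower from compound 1 to compound 2 (beyond the scatter) is the single measured change in the set.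

Compound 3 `Cc1nc2c(OCc3ccc(F)cc3)cccn2c1N` differs from compound 1 at another place: fluoro in place of hydrogen on an aromatic carbon. Within the data shown here, the step from compound 1 to compound 2 concerns the alkyl group on the core, not the benzyl ring, so it does not bear on the present change, and no measured step does. With nothing in the data pointing either way, the expectation is a step of no size beyond the scatter, keeping compound 3 near the top of the range.

For compound 3 the estimate in this assay is 92%, with a range from 75% to 100%, which corresponds to an expected step of a number 5 percentage points lower from compound 1 to compound 3 (within the scatter).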

Compound 3, a percentage reported as inhibition, in the whole organism at one dose (the size of the read-out at that dose, not a potency): 95%
Compound 3: the middle estimate sits 3 percentage points below what was measured, and the stated range covers the measured number.
By their numbers in this assay, from the lowest: compound 2; then compounds 3 and 1 (each within the scatter of the next).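

In this assay, within the data shown here, fluoro in place of hydrogen on an aromatic carbon of the benzyl ring, para to a large group, gives a number 2 percentage points lower from compound 1 to compound 3 (within the scatter), so this place accepts the fluoro with no step that stands out from the scatter. The earlier pair spoke only to the alkyl group on the core, where isopropyl in place of methyl gives a number 73 percentage points lower from compound 1 to compound 2 (beyond the scatter); the benzyl ring now has one measured change of its own, and within these three compounds the large step belongs to the core change alone. The data in hand hold nothing that explains either result.

Still open, going by these compounds, is whether this tolerance extends beyond a single fluorine atom, for instance to chloro, methoxy, trifluoromethyl or an amine at the same place, or to fluoro on the other carbons of the benzyl ring. Also open, on these data alone, is whether fluoro would leave the number unchanged on the isopropyl background of compound 2, and since the read-out comes from one dose, it shows only the size of the effect of compound 1 and compound 3 at that dose, and whether either would give a stronger or weaker effect at any other dose cannot be judged from it.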